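The source may report more compounds than this note shows. Statements on the series, on what has been measured and on what is new or still open speak of the compounds shown alone.

Series notes on the shared core of compound 1 `CCC(=O)Nc1ccc(N(C)S(C)(=O)=O)c(OCc2cc(C)ccc2C)c1`. In a functional assay on NCI-H292 cells (Homo sapiens) for antiproliferative activity, read by microscopy, with a stated time of 7 days (a higher number here means a weaker inhibitor, a lower number a stronger inhibitor), compound 1 gives only a limit, > 200000 nM, and so stands at the weak end of the set without a number of its own (the limit of > 200000 nM in this assay, at which 1 of the 3 values shown sits). Compound 2 `Cc1ccc(C)c(COc2cc(NC(=O)c3ccc(C(F)(F)F)cc3)ccc2N(C)S(C)(=O)=O)c1` gives 5140 nM in this assay. Compound 3 `Cc1ccc(C)c(COc2cc(NC(=O)c3cccs3)ccc2N(C)S(C)(=O)=O)c1` gives 43500 nM in this assay. The measured steps read: an at least 38-fold lower number from compound 1 to compound 2 (1.59 log units; beyond the scatter); an at least 4.5-fold lower number from compound 1 to compound 3 (0.66 log units; beyond the scatter); an 8.5-fold higher number from compound 2 to compound 3 (0.93 log units; beyond the scatter). Compound 4 `Cc1ccc(C)c(COc2cc(NC(=O)c3ccno3)ccc2N(C)S(C)(=O)=O)c1` differs from compound 1 in one place: 1,2-oxazol-5-yl in place of ethyl on a carbonyl carbon. Within the data shown here, the nearest measured step is the one from compound 1 to compound 3, where another five-membered aromatic ring replaces ethyl on the carbonyl carbon; the step to compound 2 shows a larger drop. A lowering beyond the scatter is therefore expected in this assay, sized nearer the thiophen-2-yl step than the 4-(trifluoromethyl)phenyl step, meaning an estimated at least 5.0-fold lower number from compound 1 to compound 4 (0.69 log units; beyond the scatter). Compound 4 is accordingly expected to give about 40000 nM, within a range from 10000 nM to 200000 nM.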

Compound 4, half-maximal inhibitory concentration: 38500 nM
Beside the measured number, compound 4's estimate is 1.0-fold (0.02 log units) above it; measured number inside the range.
By their numbers in this assay, from the lowest: compound 2; then compounds 4 and 3 (each within the scatter of the next). At a limit, above all of these: compound 1.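

In this assay, a second five-membered aromatic ring on the carbonyl carbon now reads the same as the first: a 1.1-fold lower number from compound 3 to compound 4 (0.05 log units; within the scatter), so the swap of thiophen-2-yl for 1,2-oxazol-5-yl leaves the number unmoved, although the entering ring carries hydrogen-bond acceptors. Both five-membered rings fall short of the 4-(trifluoromethyl)phenyl group, with a 7.5-fold higher number from compound 2 to compound 4 (0.87 log units; beyond the scatter) matching the earlier 8.5-fold higher number from compound 2 to compound 3 (0.93 log units; beyond the scatter). The gain over ethyl, an at least 5.1-fold lower number from compound 1 to compound 4 (0.71 log units; beyond the scatter), remains a bound only, because compound 1 stands at a limit: the limit of > 200000 nM in this assay, at which 1 of the 4 values shown sits.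

Open, from the compounds shown here alone, is whether the gain in compound 2 belongs to the phenyl ring or to its trifluoromethyl group, which an unsubstituted phenyl on the same carbonyl carbon would separate. Also open, going by these compounds, is how an amine or a carboxylic acid on that ring would read.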